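This account rests on a few compounds, and the source may have more. Where it says the series, first, only, none or still open, it means among the compounds named here.

Measured so far in a functional assay on LoVo cells (Homo sapiens) for cytotoxicity, read by colorimetric assay and MTT assay; on this read-out higher numbers stand for weaker inhibition and lower numbers for stronger inhibition:
- compound 1 `COc1ccc(-c2cc3c(OC)ccc(OC)c3nc2O)cc1` gives 10000 nM
- compound 2 `CCN(CC)C(=O)Cn1c(=O)c(-c2ccc(OC)cc2)cc2c(OC)cc(OC)cc21` gives 10000 nM

Compound 2 stands level with compound 1 on these numbers, the two values lying within the scatter of each other. Compound 3 `COc1ccc(-c2cc3c(OC)cc(OC)cc3n(CCC(=O)OCc3ccccc3)c2=O)cc1` is still to be measured. It carries (benzyloxycarbonyl)methyl in place of diethylcarbamoyl on a saturated chain carbon bound to an aromatic nitrogen, and the counted difference from compound 2 is (benzyloxycarbonyl)methyl in place of diethylcarbamoyl on a saturated chain carbon bound to an aromatic nitrogen in full. Among the measured compounds shown here, no measured pair shows a change of this kind, so the expectation rests only on compound 2 at 10000 nM as the starting point. No change beyond the scatter is expected in this assay, and the estimated step of a 1.3-fold lower number from compound 2 to compound 3 (0.10 log units; within the scatter) is small. For compound 3 the estimated value is 8000 nM with an expected range from 2500 nM to 20000 nM as the working figure.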

Compound 3, half-maximal inhibitory concentration: 10000 nM
The estimate for compound 3 lay 1.3-fold (0.10 log units) below the measured number; the measured number falls inside the stated range.
By their numbers in this assay, from the lowest: compounds 1, 2 and 3 (each within the scatter of the next).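

In this assay, (benzyloxycarbonyl)methyl in place of diethylcarbamoyl on a saturated chain carbon bound to an aromatic nitrogen gives no change at the digits printed from compound 2 to compound 3 (within the scatter) as the first step read at this position. The entering group carries a six-membered aromatic ring of carbon only, which diethylcarbamoyl lacks, and this difference leaves no mark on the read-out. No measurement is at hand that bears on this result.

With a single step read, the compounds shown leave open whether any change at this position can move the number away from the level of compound 2. A carboxylic acid or a tertiary amine at the end of this chain would put that question to a different kind of group.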